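The source may report more compounds than this note shows. Statements on the series, on what has been measured and on what is new or still open speak of the compounds shown alone.

Compound 1, with the structure `CCCCCCCC/C=C\CCCCCCCCNC(=O)Nc1c(C)cccc1C`, is a urea that carries a long unsaturated chain on one nitrogen and an aromatic ring on the other. In an assay on microsomes from intestinal mucosa for inhibition of acyl-CoA:cholesterol acyltransferase (Oryctolagus cuniculus) (on this read-out higher numbers stand for weaker inhibition and lower numbers for stronger inhibition), compound 1 gives 160 nM, the lowest single number among the values shown here. Compound 2, `CCCCCCCCCCCCCCCCCCNC(=O)Nc1c(C)cccc1C`, has the same aromatic ring but a fully saturated chain, and in this assay compound 2 gives 610 nM; 610 nM (2 entries). Compound 3, `CCCCCCCCCCCCCCCCCC[S+]([O-])c1c(C)cccc1C`, replaces the urea with a sulfoxide link; for compound 3 this assay reports only a limit, > 10000 nM, which is the limit of > 10000 nM in this assay, at which 1 of the 3 values shown sits.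

Compound 4, `CCCCCCCC/C=C\CCCCCCCCNC(=O)Nc1ccccc1CC`, has not yet been measured. It differs from compound 1 in one place: 2-ethylphenyl in place of 2,6-dimethylphenyl on an amide-type nitrogen. Within the data shown here, no step between two measured compounds covers this kind of change, so the expectation rests on the shape of compound 1 alone. The step from compound 1 to compound 4 is expected to be modest and toward weaker inhibition, a 3.1-fold higher number from compound 1 to compound 4 (0.49 log units; beyond the scatter). Compound 4 is therefore estimated at 500 nM in this assay, within a range from 150 nM to 1500 nM.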

Compound 4, half-maximal inhibitory concentration: 980 nM
Compound 4: the middle estimate sits 2.0-fold (0.29 log units) below what was measured, within the range that was stated.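

In this assay, among these compounds, putting 2-ethylphenyl in place of 2,6-dimethylphenyl on the amide-type nitrogen gives a 6.1-fold higher number from compound 1 to compound 4 (0.79 log units; beyond the scatter), the first view of a change at this group, since compounds 1, 2 and 3 all carry 2,6-dimethylphenyl. The two groups hold the same atoms, joined differently, and have no hydrogen-bond donors, acceptors or net charge, so the reading here depends on how those atoms are arranged and not only on which atoms are present. Nothing measured here explains why this rearrangement weakens inhibition.

With no 2-methylphenyl, plain phenyl or 2,6-diethylphenyl group among the compounds, the effect of removing one methyl cannot be separated from that of lengthening the other to ethyl. Going by these compounds, whether the same swap would weaken inhibition on the saturated chain of compound 2 also remains open.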